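The source may report more compounds than this note shows. Statements on the series, on what has been measured and on what is new or still open speak of the compounds shown alone.

The three measured compounds share one core, seen in compound 1 `Cc1cc(=O)n(-c2ccccc2C(F)(F)F)nc1C(=O)Nc1ccc(Oc2ncnc3sccc23)cc1`, compound 2 `Cc1cc(=O)n(-c2ccccc2OC(F)(F)F)nc1C(=O)Nc1ccc(Oc2ncnc3sccc23)c(F)c1` and compound 3 `O=C(Nc1ccc(Oc2ncnc3ccsc23)c(F)c1)c1nn(-c2ccc(F)cc2)ccc1=O`. In a functional assay on MCF7 cells (Homo sapiens) for cytotoxicity, read by MTT assay, with a stated time of 72 h (a lower number here means a stronger inhibitor, a higher number a weaker inhibitor), compound 1 gives only a limit, > 40000 nM. Compound 2 likewise reaches only a limit, > 40000 nM. Going by the values given here, compound 3 is the single compound with a number, 5720 nM. Two of the three values are thus limits: the limit of > 40000 nM in this assay, at which 2 of the 3 values shown sit. Compound 4 `O=C(Nc1ccc(Oc2ncnc3ccsc23)c(F)c1)c1nn(-c2ccccc2)ccc1=O` differs from compound 3 by hydrogen in place of fluoro on an aromatic carbon. Among the compounds with values here, no measured pair shows this change, so the step from compound 3 to compound 4 is expected to stay within the scatter, a 1.1-fold higher number from compound 3 to compound 4 (0.06 log units; within the scatter). Compound 4 is therefore estimated at 6500 nM, between 2500 nM and 18000 nM.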

Compound 4, half-maximal inhibitory concentration: 12400 nM
Beside the measured number, compound 4's estimate is 1.9-fold (0.28 log units) below it; the range from low to high includes it.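

Going by these compounds alone, the change from 4-fluorophenyl to phenyl gives the only one-place comparison so far in this assay, and it reads as a 2.2-fold higher number from compound 3 to compound 4 (0.34 log units; beyond the scatter). The fluoro on this aromatic carbon, para to a large group, therefore makes a measurable though modest difference in this single pair. Nothing shown here accounts for that difference. From the compounds shown here alone, whether a chlorine, a methoxy group or an amine at this position would give a lower number stays open. Compound 1 and compound 2 each give only a limit, so they say nothing about this position.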